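A few compounds are considered here, and "the series" means these few. Any claim that something is new, unique, unknown or untested is made for them only; others in the source may bear on it.

The measured compounds are:

compound 1, `OC1CNCc2nc(-c3ccc(N4CCCC4)cc3)sc21`, 730 nM
compound 2, `Cc1cc(N(C)C)ccc1-c1nc2c(s1)[C@H](O)CCC2`, 270 nM
compound 3, `OC1CCCc2nc(-c3ccc(N4CCCC4)cc3)sc21`, 1530 nM

All three were run in a functional assay on HCT-116 cells (Homo sapiens) for cytotoxicity, read by sulforhodamine B assay, with a stated time of 2 days; a higher number here means a weaker inhibitor, a lower number a stronger inhibitor. Among these three numbers compound 1 stands second highest. Its nearest neighbour is compound 3, whose number is higher than that of compound 1 and lies beyond the scatter; the furthest is compound 2, whose number is lower than that of compound 1 and also lies beyond the scatter. Among the compounds with values here, the three compounds differ in more than one place at a time, so no single step between any two of them can be isolated from these numbers.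

Compound 4, `OCc1cc(N2CCCC2)ccc1-c1nc2c(s1)C(O)CNC2`, has not yet been measured in this assay. It differs from compound 1 in one place: hydroxymethyl in place of hydrogen on an aromatic carbon. Within the data shown here, no pair of measured compounds shows what this change does, so there is nothing in these data to argue for a step in either direction. The expectation is therefore for a change that stays within the scatter, with the number for compound 4 near that of compound 1. The estimated step is a 1.0-fold lower number from compound 1 to compound 4 (0.02 log units; within the scatter). In this assay compound 4 is expected to give about 700 nM, with a likely range from 250 nM to 2000 nM.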

Compound 4, half-maximal inhibitory concentration: 70 nM
For compound 4 the middle estimate is 10-fold (1.00 log units) above the measured one; the measured number lies below the stated range.
By their numbers in this assay, from the lowest: compound 4; then compound 2; then compound 1; then compound 3.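

In this assay, hydroxymethyl in place of hydrogen gives a 10-fold lower number from compound 1 to compound 4 (1.02 log units; beyond the scatter) and so moves the number well beyond the scatter. Within the data shown here, this is the first single change that can be read, since the earlier compounds differed in more than one place and said nothing about this aromatic carbon, ortho to a large group and meta to a pyrrolidin-1-yl group; it shows that the position is sensitive to substitution and that this group, at least, goes with a stronger inhibitor. No measurement at hand bears on why the step is so large.

The compounds shown do not tell whether the step belongs to the hydroxymethyl group itself or would also come with a methyl, a methoxymethyl or an aminomethyl group on the same carbon, so a single pair cannot separate the role of the oxygen from that of the added carbon. They also leave open whether the same change would give a step of similar size on the core of compound 3 or in any other cell line.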